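The source may hold more compounds than are shown below. What is called first, only, known or untested is meant among the compounds shown, and "the series" means these compounds.

Measured compounds:
- compound 1 `ClCc1ccccc1Cn1cnc2c(Cl)nc(Cl)nc21`: "not determined" (no result reported)
- compound 2 `ClCc1cccc(Cn2cnc3ncnc(Cl)c32)c1`: 6760 nM

Within the data shown here, in a functional assay on SNB-19 cells (Homo sapiens) for cytotoxicity, read by sulforhodamine B assay, with a stated time of 48 h (on this read-out higher numbers stand for lower toxicity in this test and lower numbers for higher toxicity in this test), compound 2 gives 6760 nM and is the only compound of the series with a number; compound 1 has no result in this assay, so no step between measured compounds can be drawn, and nothing is known about how a change on the shared core moves this read-out.

Compound 3 `ClCc1cccc(Cn2cnc3nc(Cl)nc(Cl)c32)c1` differs from compound 2 by chloro in place of hydrogen on an aromatic carbon. Among the measured compounds shown here, no measured step is available to size this change. Without such a step, the expected step from compound 2 to compound 3 is a 1.4-fold lower number from compound 2 to compound 3 (0.13 log units; within the scatter), no larger than the usual scatter and in no firm direction. Compound 3 is therefore estimated at 5000 nM in this assay, with a range from 1500 nM to 15000 nM, to be settled by the measurement itself.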

Compound 3, concentration lethal to 50% of the cells: 5120 nM
Compound 3: middle estimate off by 1.0-fold (0.01 log units), on the low side, and the stated range covers the measured number.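

In this assay, among these compounds, chloro in place of hydrogen on an aromatic carbon between two ring nitrogen atoms gives a 1.3-fold lower number from compound 2 to compound 3 (0.12 log units; within the scatter) and is the first step that can be read. For this one pair, the read-out does not separate chloro from hydrogen at this position, so the added chloro leaves the toxicity reading within the usual scatter. No measured information on the compounds bears on this result.

Steps involving compound 1 cannot be read, so the effect of moving the chloromethyl group on the other ring stays unknown. Going by these compounds, it also remains open whether a larger or differently built group at the same aromatic carbon, such as an amine or a longer chain, would move this read-out beyond the scatter.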